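A few compounds are considered here, and "the series" means these few. Any claim that something is new, unique, unknown or untested is made for them only; others in the source may bear on it.

Compound 3 `FC(F)(F)c1ccc(NC(=S)N/N=C/c2ccc3ccccc3n2)cc1` gives 59100 nM in a functional assay on HeLa cells (Homo sapiens) for antiproliferative activity, read by sulforhodamine B assay, with a stated time of 72 h; a higher number here means a weaker inhibitor, a lower number a stronger inhibitor. That is the lowest of the two numbers in this assay, yet the nearest of them, compound 1 `COc1cccc(NC(=S)N/N=C/c2ccc3ccccc3n2)c1` at 74500 nM, lies within the scatter of it, so no order between the two can be read. Compound 2 `S=C(N/N=C/c1ccc2ccccc2n1)Nc1ccc(Cl)cc1` returns only a limit of the assay, > 100000 nM. Compound 4 `COc1ccc(NC(=S)N/N=C/c2ccc3ccccc3n2)cc1` has not yet been measured; it differs from compound 3 by methoxy in place of trifluoromethyl on an aromatic carbon. Within the data shown here, two measured steps bear on that change. The step of an at least 1.3-fold higher number from compound 1 to compound 2 (0.12 log units; that floor lies within the scatter) trades a 3-methoxyphenyl for a 4-chlorophenyl on an amide-type nitrogen, and the step of an at least 1.6-fold lower number from compound 2 to compound 3 (0.22 log units; that floor lies within the scatter) puts a trifluoromethyl in place of a chloro on an aromatic carbon. Each of those steps is a floor only, because of the limit of > 100000 nM in this assay, at which 1 of the 3 values shown sits, at which compound 2 sits, and neither floor exceeds the scatter. Compound 1 already carries a methoxy group, and its number sits within the scatter of compound 3. No shown step therefore points to a change beyond the scatter, in either direction, in this assay. The expected step is accordingly a 1.2-fold higher number from compound 3 to compound 4 (0.07 log units; within the scatter), no more than the scatter. Compound 4 is estimated at 70000 nM, with a range from 35000 nM to 140000 nM, and a real chance that only a limit is reported.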

Compound 4, half-maximal inhibitory concentration: 72600 nM
Estimate against measurement, compound 4: 1.0-fold (0.02 log units) below, within the range that was stated.
By their numbers in this assay, from the lowest: compounds 3, 4 and 1 (each within the scatter of the next). At a limit, above all of these: compound 2.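

In this assay, the exchange at this position, para to a large group, gives a 1.2-fold higher number from compound 3 to compound 4 (0.09 log units; within the scatter). Among these compounds, this is the first direct comparison of trifluoromethyl and methoxy on the same aromatic carbon, and it shows no difference that can be read, although the two groups differ in their heavy atoms and methoxy brings a hydrogen-bond acceptor. Moving the methoxy group gives a 1.0-fold lower number from compound 1 to compound 4 (0.01 log units; within the scatter), so 4-methoxyphenyl and 3-methoxyphenyl on the amide-type nitrogen also cannot be told apart here, while the comparison with chloro, an at least 1.3-fold lower number from compound 2 to compound 4 (0.13 log units; that floor lies within the scatter), remains a floor set by a limit of the assay: the limit of > 100000 nM in this assay, at which 1 of the 4 values shown sits.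

The compounds shown leave open whether an amine, a carboxylic acid or a longer alkoxy chain on this aromatic carbon would give a step beyond the scatter, since none of the readable steps among these aryl groups goes that far. They also leave open whether a change to the shared core, rather than to the aryl group on the amide-type nitrogen, would move the number further than any of these exchanges.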